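From Phenyl to Tert-Butyl: What Two Measurements Suggest

A few compounds are considered here, and "the series" means these few. Any claim that something is new, unique, unknown or untested is made for them only; others in the source may bear on it.

The measurements come from an assay on NIH3T3 cells with Urotensin-2 receptor (Homo sapiens) as the target (on this read-out lower numbers stand for smaller maximal responses and higher numbers for larger maximal responses), with two compounds measured so far:

Compound 1 `COc1ccc(NC(=O)NC(CCN(C)C)c2ccc(Cl)cc2)cc1` gives 195%.
Compound 2 `CN(C)CCC(NC(=O)Nc1ccc(-c2ccccc2)cc1)c1ccc(Cl)cc1` gives 91%.

Compound 2 stands lowest of these two numbers; its nearest neighbour is compound 1, which lies a number 104 percentage points lower from compound 1 to compound 2 (beyond the scatter) in reverse, that is, compound 1 sits well above it. Among the measured compounds shown here, the one measured step, the move from compound 1 to compound 2, is a number 104 percentage points lower from compound 1 to compound 2 (beyond the scatter), beyond the scatter.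

Compound 3 `CN(C)CCC(NC(=O)Nc1ccc(C(C)(C)C)cc1)c1ccc(Cl)cc1` is not yet measured. It differs from compound 2 as follows: tert-butyl in place of phenyl on an aromatic carbon. For the measured compounds named here, no measured step shows what trading the phenyl for the tert-butyl does; the only step known replaces methoxy with phenyl and is large. Since that step moved the number a long way, a change at the same place is taken to be capable of a sizeable shift, but with no direction fixed by the data.

For compound 3 the expected result is 120%, within 70% to 180%, which is estimated to mean a number 29 percentage points higher from compound 2 to compound 3 (beyond the scatter).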

Compound 3, largest response reached (reported as efficacy), in percent of the reference or control that the assay uses: 103%
Beside the measured number, compound 3's estimate is 17 percentage points above it; measured number inside the range.
By their numbers in this assay, from the lowest: compound 2; then compound 3; then compound 1.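

In this assay, tert-butyl in place of phenyl gives a number 12 percentage points higher from compound 2 to compound 3 (beyond the scatter), a modest step, whereas tert-butyl in place of methoxy gives a number 92 percentage points lower from compound 1 to compound 3 (beyond the scatter), a large one. Compound 2 and compound 3 therefore both lie far under compound 1, which shows that at this aromatic carbon a second ring is not needed for most of the drop: tert-butyl has no ring and still lands much closer to phenyl than to methoxy. The data offer no explanation for why methoxy stands so far apart from these two groups or why tert-butyl sits a little higher than phenyl.

Among the compounds shown here, with only three groups at this position, it remains open whether the high number belongs to methoxy alone or would also appear with a group such as an amine, a hydroxyl or a carboxylic acid in the same place. Going by these compounds, it is equally open whether these steps would keep their size if the chlorine on the other ring or the dimethylamino chain were changed, as all three compounds share those parts.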